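The compounds below may be only part of what the source reports. "The series", "measured", "known", "first", "only" and "open" are said of these compounds alone.

Measured so far in an assay on isolated protein (strain Sprague-Dawley) for inhibition of Amine oxidase [flavin-containing] B (Rattus norvegicus), read by spectrophotometry, with a stated time of 5 min; a higher number here means a weaker inhibitor, a lower number a stronger inhibitor:
compound 1 `CCCOc1cc(=O)oc2cc(OCc3cccc(F)c3)ccc12` gives 407 nM
compound 2 `COCOc1cc(=O)oc2cc(OCc3cccc(Cl)c3)ccc12` gives 100 nM

Of these two numbers compound 2 holds the lower one; compound 1 stands higher by a gap that goes beyond the usual scatter. Compound 3 `O=C(COc1cc(=O)oc2cc(OCc3cccc(Cl)c3)ccc12)N1CCCCC1` has not yet been measured in this assay. It differs from compound 2 by (piperidin-1-yl)carbonyl in place of methoxy on a saturated chain carbon bound to an oxygen on an aromatic ring. Going by the values given here, no comparable step exists among the measured compounds, so the expectation rests on the change alone. The step of a 3.0-fold higher number from compound 2 to compound 3 (0.48 log units; beyond the scatter) is expected to run toward a weaker inhibitor and to exceed the scatter only modestly. Compound 3 is accordingly estimated at 300 nM, with a range from 60 nM to 1500 nM.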

Compound 3, half-maximal inhibitory concentration: 38900 nM
Compound 3: the middle estimate sits 130-fold (2.11 log units) below what was measured; the measured number lies above the stated range.
By their numbers in this assay, from the lowest: compound 2; then compound 1; then compound 3.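

In this assay, putting (piperidin-1-yl)carbonyl in place of methoxy on a saturated chain carbon bound to an oxygen on an aromatic ring gives a 390-fold higher number from compound 2 to compound 3 (2.59 log units; beyond the scatter), a large step toward a weaker inhibitor. Going by these compounds alone, this position is therefore far from indifferent to what it carries, a point the earlier compounds, which differ in more than one place, could not show. Nothing at hand accounts for the loss.

From the compounds shown here alone, whether it follows from the carbonyl or from the piperidine ring remains open. A dimethylamide or a piperidin-1-yl group without the carbonyl would separate the two.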